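From Difluorophenyl to Methoxyphenyl: What Compound 4 Should Show

The compounds below may be only part of what the source reports. "The series", "measured", "known", "first", "only" and "open" are said of these compounds alone.

Compound 1 `CCCN1CCC(c2noc(COc3ccc(/C=C/C(=O)NO)cc3)n2)CC1` gives 69%
Compound 2 `Cc1ccccc1CN1CCC(c2noc(COc3ccc(/C=C/C(=O)NO)cc3)n2)CC1` gives 68%
Compound 3 `O=C(/C=C/c1ccc(OCc2nc(C3CCN(Cc4ccc(F)c(F)c4)CC3)no2)cc1)NO` gives 60%

Three compounds share a core and differ only in the group on a saturated chain carbon bound to an amine nitrogen in a ring. In an assay on isolated protein for inhibition of protein deacetylase HDAC6 (Homo sapiens), read by fluorescence, with a stated time of 1 h, tested at 100 nM (a higher number here means more inhibition at the concentration tested (going by the name of the read-out), a lower number less inhibition), compound 1 gives 69%, compound 2 gives 68% and compound 3 gives 60%. Compound 3 has the lowest of the three numbers, yet every step onto it stays within the scatter: a number 9 percentage points lower from compound 1 to compound 3 (within the scatter) and a number 8 percentage points lower from compound 2 to compound 3 (within the scatter). Between compounds 1 and 2 the difference is a number 1 percentage points lower from compound 1 to compound 2 (within the scatter). None of the three groups therefore separates from the others.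

Compound 4 `COc1ccc(CN2CCC(c3noc(COc4ccc(/C=C/C(=O)NO)cc4)n3)CC2)cc1` continues this series: 4-methoxyphenyl in place of 3,4-difluorophenyl on a saturated chain carbon bound to an amine nitrogen in a ring. Going by the values given here, no measured step covers this exact exchange. Among the compounds with values here, the steps that bear on it are those in which one aryl group on that carbon replaces another or replaces ethyl, and all of them were small. Compound 4 is therefore expected to sit near its neighbours, with an expected step of a number 5 percentage points higher from compound 3 to compound 4 (within the scatter) that does not exceed the scatter. The estimate for compound 4 in this assay is 65%, with a range from 50% to 78%.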

Compound 4, a percentage reported as inhibition, at one concentration (the size of the read-out at that concentration, not a potency): 75%
Beside the measured number, compound 4's estimate is 10 percentage points below it; the range from low to high includes it.
By their numbers in this assay, from the lowest: compounds 3, 2, 1 and 4 (each within the scatter of the next, the first and the last beyond it).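

In this assay, going by these compounds alone, the group on a saturated chain carbon bound to an amine nitrogen in a ring now yields its first separation, with a number 15 percentage points higher from compound 3 to compound 4 (beyond the scatter) as the only step that clears the scatter. The separation holds for this pair alone: the other two steps onto 4-methoxyphenyl are a number 7 percentage points higher from compound 2 to compound 4 (within the scatter) and a number 6 percentage points higher from compound 1 to compound 4 (within the scatter) so compound 4 does not separate from the compounds carrying ethyl or 2-methylphenyl. The exchange of 3,4-difluorophenyl for 4-methoxyphenyl removes two fluorine atoms and brings in one oxygen and one hydrogen-bond acceptor by count, but no measurement shown ties the step to any of these differences.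

As far as these compounds go, whether the step follows the entry of methoxy or the departure of fluorine stays open, and a plain phenyl or a 4-fluorophenyl on that carbon would help to tell the two apart. Every number shown is also read at a single concentration, so the series gives the size of inhibition at that concentration and leaves the potency of these compounds open.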